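Bromophenyl sulfonate replacing methoxyphenyl on a weak series

The source may report more compounds than this note shows. Statements on the series, on what has been measured and on what is new or still open speak of the compounds shown alone.

Of the compounds shown here, three have been tested in a functional assay on DU-145 cells (Homo sapiens) for inhibition, read by MTT assay, with a stated time of 72 h; on this read-out higher numbers stand for weaker inhibition and lower numbers for stronger inhibition. Compound 1 `O=S(=O)(Oc1ccccc1)[C@H]1C[C@H]2O[C@@H]1C(c1ccc(O)cc1)=C2c1ccc(O)cc1` is reported only at the limit of this assay, > 100000 nM, and gives no number. Compound 2 `O=C(O)CCCCCCC(=O)Nc1ccc(C2=C(c3ccc(O)cc3)C3CC(S(=O)(=O)Oc4cccc5ccccc45)C2O3)cc1` gives 48600 nM in this assay. Compound 3 `COc1ccccc1OS(=O)(=O)C1CC2OC1C(c1ccc(NC(=O)CCCCCCC(=O)NO)cc1)=C2c1ccc(O)cc1` gives 44700 nM in this assay, which is the lower of the two numbers, though compound 2 lies within the usual scatter of it, so the two cannot be told apart. Within the data shown here, no pair of these measured compounds differs in one place, so no single step has a measured size.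

Compound 4 `O=C(CCCCCCC(=O)Nc1ccc(C2=C(c3ccc(O)cc3)C3CC(S(=O)(=O)Oc4ccc(Br)cc4)C2O3)cc1)NO` is the next compound and has not been measured. It differs from compound 3 in one place: 4-bromophenyl in place of 2-methoxyphenyl on an oxygen. Among the measured compounds shown here, nothing among the measured compounds sets a size for this kind of change. Compound 3 and compound 2 show that two different aryl groups on that oxygen give numbers within the scatter of each other, so the step from compound 3 to compound 4 is expected to stay within the scatter, as a 1.1-fold lower number from compound 3 to compound 4 (0.03 log units; within the scatter). Compound 4 is therefore expected to give about 42000 nM in this assay, estimated within 15000 nM to 100000 nM.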

Compound 4, half-maximal inhibitory concentration: 11300 nM
Compound 4: middle estimate off by 3.7-fold (0.57 log units), on the high side, outside the stated range (below it).
By their numbers in this assay, from the lowest: compound 4; then compounds 3 and 2 (each within the scatter of the next). At a limit, above all of these: compound 1.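

Among these compounds, putting 4-bromophenyl in place of 2-methoxyphenyl on the oxygen attached to the sulfonyl sulfur gives a 4.0-fold lower number from compound 3 to compound 4 (0.60 log units; beyond the scatter) in this assay, and this is the first measured step at this position. It shows that the number in this series responds to the aryl group on that oxygen by more than the scatter, although the step is only modest. Nothing measured here says which feature of this exchange produces the step.

The exchange alters both the substituent and its place on the phenyl ring, so the compounds shown cannot separate the two, and 4-methoxyphenyl or 2-bromophenyl on the same oxygen would be needed to do so. Going by these compounds, it also remains open whether another halogen, such as 4-chlorophenyl or 4-fluorophenyl, would give a similar number.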